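Changing the outer aromatic ring: from compound 2 to compound 3

A few compounds are considered here, and "the series" means these few. Any claim that something is new, unique, unknown or untested is made for them only; others in the source may bear on it.

Measured so far in an assay on cells for agonist activity at probable G-protein coupled receptor 34 (Mus musculus), with a stated time of 1 h; a higher number here means a larger maximal response, a lower number a smaller maximal response:
- compound 1, `CCCCCCCCCCCOc1ccccc1CCC(=O)OCCCOP(=O)(O)OC[C@H](N)C(=O)O`, gives 14.6%
- compound 2, `N[C@@H](COP(=O)(O)OCCCOC(=O)CCc1ccccc1OCc1cccc(Oc2cccc(Cl)c2)c1)C(=O)O`, gives 17.1%

Compound 2 shows the higher of the two numbers, but the gap to compound 1 lies within the usual scatter of this assay, so the two cannot be told apart on these data. Among the compounds with values here, no step between two measured compounds that differ in only one place has been recorded, so there is no measured guide to how a change at the outer end of the shared core plays out.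

Compound 3, `CC(C)(C)c1ccc(Oc2cccc(COc3ccccc3CCC(=O)OCCCOP(=O)(O)OC[C@H](N)C(=O)O)c2)cc1`, is the compound not yet measured. It differs from compound 2 in one place: 4-(tert-butyl)phenyl in place of 3-chlorophenyl on an oxygen on an aromatic ring. In this assay the only knowledge available is that both measured compounds sit at a similar, modest maximal response.

With nothing beyond that, compound 3 is expected to sit close to compound 2, and the step of a number 0.9 percentage points higher from compound 2 to compound 3 (within the scatter) is estimated to stay within the scatter. The estimate for compound 3 is therefore 18%, with a range from 8% to 30%.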

Compound 3, largest response reached (Emax), in percent of the reference or control that the assay uses: 16.9%
For compound 3 the middle estimate is 1.1 percentage points above the measured one; low and high end bracket the measured number.
By their numbers in this assay, from the lowest: compounds 1, 3 and 2 (each within the scatter of the next).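

In this assay, the step at the outer aromatic ring reads a number 0.2 percentage points lower from compound 2 to compound 3 (within the scatter), so replacing 3-chlorophenyl with 4-(tert-butyl)phenyl on an oxygen on an aromatic ring gives no readable difference in maximal response. Within the data shown here, this is the first one-place comparison at this position, and the two groups cannot be told apart here, even though the entering group has 10 heavy atoms, all carbon, and the leaving group has 7, one of them chlorine. No supporting measurement is available to explain this result.

This single step changes both the group and the number in its name, so it cannot show whether either change alone would matter, and 4-chlorophenyl or 3-(tert-butyl)phenyl at the same place would separate the two. It also leaves open whether an outer ring carrying an amine or a carboxylic acid, both unlike the chlorine and tert-butyl groups compared so far, would move the response beyond the scatter of this assay.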